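This account rests on a few compounds, and the source may have more. Where it says the series, first, only, none or still open, it means among the compounds named here.

Measured so far:
Compound 1 `COc1ccc2nc(-c3ccc(N/C=C\C(=O)c4cc(OC)c(OC)c(OC)c4Br)c(C)c3)sc2c1` gives 23400 nM in a functional assay on MIA PaCa-2 cells (Homo sapiens) for antiproliferative activity, read by sulforhodamine B assay, with a stated time of 48 h; on this read-out lower numbers stand for stronger inhibition and higher numbers for weaker inhibition.
Compound 2 `COc1ccc2nc(-c3ccc(N/C=C\C(=O)c4cc(OC)c(OC)c(OC)c4Br)cc3)sc2c1` gives 14700 nM.
Compound 3 `COc1cc(C(=O)/C=C\Nc2ccc(-c3nc4cc(OC)c(OC)c(OC)c4s3)cc2C)cc(OC)c1OC` gives 22800 nM.

Compound 1 and compound 2 differ in one place: hydrogen in place of methyl on an aromatic carbon. That change made a 1.6-fold lower number from compound 1 to compound 2 (0.20 log units; within the scatter). Among the measured compounds shown here, compound 3 carries a different core; how the core of compound 3 differs from the core of compound 1 is not broken down here, and the two values show only that compound 3 and compound 1 stand close together.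

Compound 4 `COc1cc(C(=O)/C=C\Nc2ccc(-c3nc4cc(OC)c(OC)c(OC)c4s3)cc2)cc(OC)c1OC` is not yet measured. It differs from compound 3 in one place: hydrogen in place of methyl on an aromatic carbon. This is the same kind of change as that from compound 1 to compound 2, though around the place the surroundings are described differently: in compound 1 the carbon is meta to a 6-methoxy-1,3-benzothiazol-2-yl group, in compound 3 it is meta to a large group. The step that this expectation means is a 1.5-fold lower number from compound 3 to compound 4 (0.18 log units; within the scatter), resting on the earlier step, which gave a 1.6-fold lower number from compound 1 to compound 2 (0.20 log units; within the scatter). Compound 4 is therefore expected to give about 15000 nM, roughly between 7000 nM and 32000 nM.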

Compound 4, half-maximal inhibitory concentration: 29100 nM
The estimate for compound 4 lay 1.9-fold (0.29 log units) below the measured number; measured number inside the range.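

In this assay, putting hydrogen in place of methyl on this aromatic carbon gave a 1.3-fold higher number from compound 3 to compound 4 (0.11 log units; within the scatter), so on this core the swap produced no change that can be told apart from the usual noise of repeated measurement. Set beside the same swap on the other core, this step gives no sign that the core alters the outcome: the same change on two cores in this assay, a 1.6-fold lower number (0.20 log units; within the scatter) from compound 1 to compound 2 and a 1.3-fold higher number (0.11 log units; within the scatter) from compound 3 to compound 4, 2.0-fold (0.31 log units) apart, within the scatter of two such steps. This supports carrying the swap between these two cores as a change too small to read, but it does not show that methyl or hydrogen is the better choice on either core, and two pairs say nothing about other cores.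

Only methyl and hydrogen are shown on this carbon, so it remains open whether an ethyl group, a fluorine or an amine there would move the number beyond the scatter. From the compounds shown here alone, whether such a group would behave alike on both cores also remains open.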